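Swapping an ether chain for a hydroxy group on the shared core

This account rests on a few compounds, and the source may have more. Where it says the series, first, only, none or still open, it means among the compounds named here.

Of the compounds shown here, three with the same core have been tested in an assay on isolated protein for inhibition of Polyunsaturated fatty acid 5-lipoxygenase (Rattus norvegicus); on this read-out higher numbers stand for weaker inhibition and lower numbers for stronger inhibition. Compound 1 `CCCOCC1CN(c2ccccc2)NC1=O` gives 260 nM, compound 2 `COCCC1CN(c2ccccc2)NC1=O` gives 480 nM; 10300 nM; 350 nM (3 entries), and compound 3 `CCOCCC1CN(c2ccccc2)NC1=O` gives 150 nM. Compound 3 thus has the lowest of the two single numbers, with compound 1 closest, and the step of a 1.7-fold lower number from compound 1 to compound 3 (0.24 log units; within the scatter) lies within the scatter. The spread of the entries for compound 2 the several entries of compound 2 in this assay, 480 nM; 10300 nM; 350 nM (3 entries) shows how widely repeated runs of this kind can scatter, so no order can be read among the three.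

Compound 4 `CC(C)(O)C1CN(c2ccccc2)NC1=O` differs from compound 3 by 1-hydroxy-1-methylethyl in place of 2-ethoxyethyl on a saturated ring carbon. Among the compounds with values here, the only measured step, from compound 1 to compound 3, exchanges one ether chain for another and stays within the scatter; no measured step exchanges an ether chain for a hydroxy-bearing group, so nothing here speaks directly to this change. The expectation for compound 4 is therefore held loosely: compound 4 is estimated at 500 nM, with a range from 120 nM to 3000 nM, which means an expected step of a 3.3-fold higher number from compound 3 to compound 4 (0.52 log units; beyond the scatter) that may well fall within the scatter.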

Compound 4, half-maximal inhibitory concentration: > 1000 nM
Compound 4 was reported as a limit (the forecaster's own chance of this, stated with the estimate: 5%); middle value at least 2.0-fold (0.30 log units) from the limit.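

In this assay compound 4 is recorded as > 1000 nM, which is a limit of the assay and not a single number. Even so, the change on this saturated ring carbon now gives steps beyond the scatter, with an at least 6.6-fold higher number from compound 3 to compound 4 (0.82 log units; beyond the scatter) when 1-hydroxy-1-methylethyl replaces 2-ethoxyethyl and an at least 3.8-fold higher number from compound 1 to compound 4 (0.58 log units; beyond the scatter) when it replaces propoxymethyl. Within the data shown here, the only earlier step, a 1.7-fold lower number from compound 1 to compound 3 (0.24 log units; within the scatter), exchanged one ether chain for another, so it gave no sign that the group at this position could matter this much, whereas both new comparisons link the hydroxy-bearing group to weaker inhibition.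

The true size of both new steps stays open, and repeated runs of this kind can differ widely, as shown by: the several entries of compound 2 in this assay, 480 nM; 10300 nM; 350 nM (3 entries) A straight 2-hydroxyethyl chain or a 2-aminoethyl chain on the same ring carbon would help show whether the hydroxy group itself or the branched shape of 1-hydroxy-1-methylethyl goes with the weaker inhibition.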